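Swapping the aryl group for thiophene in a cytotoxicity series

This account rests on a few compounds, and the source may have more. Where it says the series, first, only, none or still open, it means among the compounds named here.

Three compounds sharing one core were tested in a functional assay on A549 cells (Homo sapiens) for cytotoxicity; on this read-out lower numbers stand for an effect already at smaller amounts and higher numbers for an effect only at larger amounts of compound. Compound 1 `COC1=C(C)C(=O)/C(=C(O)/C=C/c2cccc(OC)c2)C(=O)C1(C)C` gives 2.8 ug/mL and has the lowest number of the three. Compound 2 `COC1=C(C)C(=O)/C(=C(O)/C=C/c2c(C)cccc2C)C(=O)C1(C)C` gives 8.3 ug/mL, and compound 3 `COC1=C(C)C(=O)/C(=C(O)/C=C/c2ccco2)C(=O)C1(C)C` gives 10 ug/mL. Compound 4 `COC1=C(C)C(=O)/C(=C(O)/C=C/c2cccs2)C(=O)C1(C)C` is not yet measured; it differs from compound 1 by thiophen-2-yl in place of 3-methoxyphenyl on a double-bonded chain carbon bound to a double-bonded chain carbon. Two measured steps speak to this change, both replacing the same 3-methoxyphenyl group: a 3.0-fold higher number from compound 1 to compound 2 (0.47 log units; beyond the scatter) and a 3.6-fold higher number from compound 1 to compound 3 (0.55 log units; beyond the scatter). The furan-2-yl case is the closer parallel, since thiophen-2-yl is likewise a five-membered aromatic ring with one hetero atom. A modest upward step is therefore expected, a 2.9-fold higher number from compound 1 to compound 4 (0.46 log units; beyond the scatter), and compound 4 is estimated at 8 ug/mL, within a range from 3.5 ug/mL to 18 ug/mL.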

Compound 4, concentration for half-maximal effect: 4.5 ug/mL
For compound 4 the middle estimate is 1.8-fold (0.25 log units) above the measured one; low and high end bracket the measured number.
By their numbers in this assay, from the lowest: compounds 1, 4, 2 and 3 (each within the scatter of the next, the first and the last beyond it).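

In this assay, both earlier replacements of 3-methoxyphenyl at this place moved the number beyond the scatter, whereas thiophen-2-yl does not, with a 1.6-fold higher number from compound 1 to compound 4 (0.21 log units; within the scatter). A five-membered aromatic ring therefore does not by itself decide the result: exchanging oxygen for sulfur in that ring gives a 2.2-fold lower number from compound 3 to compound 4 (0.35 log units; beyond the scatter). Against the 2,6-dimethylphenyl compound, the change gives a 1.8-fold lower number from compound 2 to compound 4 (0.27 log units; within the scatter).

No available data explain the gap between the furan-2-yl and thiophen-2-yl compounds. On these data alone, how an amine or a carboxylic acid on the ring would change the number here remains open.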